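The compounds below may be only part of what the source reports. "The series", "measured", "known", "first", "only" and "open" are said of these compounds alone.

In an ADME assay on HEp-2 cells (Homo sapiens) for cytotoxicity, read by MTT assay, with a stated time of 3 days (a lower number here means that less compound is tolerated, a higher number that more compound is tolerated), compound 1 `CC[C@H](CCn1cncn1)c1ccccc1` gives 97.7 ug/mL, the largest of the three numbers shown, though neither step away from it exceeds the scatter. Compound 2 `CC[C@@H](CCn1cncn1)c1ccccc1` gives 89.9 ug/mL, a step of a 1.1-fold lower number from compound 1 to compound 2 (0.04 log units; within the scatter), consistent with the fact that compounds 1 and 2 differ only in the configuration as drawn. Compound 3 `CC[C@H](CCn1cncn1)c1ccc(Cl)cc1` gives 50.6 ug/mL, a step of a 1.9-fold lower number from compound 1 to compound 3 (0.29 log units; within the scatter). Compound 4 `CCCC[C@H](CCn1cncn1)c1ccccc1` is the next step from compound 1, by ethyl in place of hydrogen on a saturated chain carbon, three bonds along the chain from an aromatic carbon. Neither measured step matches this change: one touches only configuration, the other an aromatic substituent, and both stay within the scatter. No step beyond the scatter is therefore expected for compound 4 in this assay, with a lower number rather than a higher one if any, and compound 4 is estimated at 70 ug/mL (range 35 ug/mL to 140 ug/mL), an expected step of a 1.4-fold lower number from compound 1 to compound 4 (0.14 log units; within the scatter).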

Compound 4, half-maximal cytotoxic concentration: 50.2 ug/mL
Beside the measured number, compound 4's estimate is 1.4-fold (0.14 log units) above it; measured number inside the range.
By their numbers in this assay, from the lowest: compounds 4, 3, 2 and 1 (each within the scatter of the next).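

In this assay, ethyl in place of hydrogen on this saturated chain carbon gives a 1.9-fold lower number from compound 1 to compound 4 (0.29 log units; within the scatter) and so stays inside the scatter, even though the change builds ethyl into butyl. This is the first change shown at this position, and it joins the configuration and chloro changes as a third step from compound 1 that stays within the scatter. Nothing available bears on the reason for this step.

From the compounds shown here alone, whether a longer chain, an amine or a carboxylic acid at this position would give a step beyond the scatter remains open. Also open, going by these compounds, is how the butyl chain of compound 4 would read with chloro on the aromatic ring or with the opposite configuration.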